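Series notes: a second chloro on compound 3

The source may report more compounds than this note shows. Statements on the series, on what has been measured and on what is new or still open speak of the compounds shown alone.

The three measured compounds share one core. Compound 1 `N#C/C(=C\N1CCN(C(=O)c2ccco2)C1=S)C(=O)Nc1ccc(Cl)cc1` gives 20200 nM in a functional assay on SF-295 cells (Homo sapiens) for inhibition, read by sulforhodamine B assay, with a stated time of 48 h; on this read-out lower numbers stand for stronger inhibition of growth and higher numbers for weaker inhibition of growth. Compound 2 `N#C/C(=C\N1CCN(C(=O)c2ccco2)C1=S)C(=O)c1ccccc1` gives 43600 nM in this assay. For the measured compounds named here, the only single-place step among the measured compounds, a 2.2-fold higher number from compound 1 to compound 2 (0.33 log units; beyond the scatter), is a modest shift at the carbonyl carbon. Compound 3 `O=CN1CCN(c2ccc(Cl)cc2)C1=S` gives 26900 nM in this assay; it stands second highest of the three numbers, within the scatter of compound 1 on one side and of compound 2 on the other, so no order among the three can be stated.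

Compound 4 `O=CN1CCN(c2ccc(Cl)c(Cl)c2)C1=S` is the next member. It differs from compound 3 by chloro in place of hydrogen on an aromatic carbon. Going by the values given here, none of the measured steps bears on this change: the single step measured, a 2.2-fold higher number from compound 1 to compound 2 (0.33 log units; beyond the scatter), concerns a substituent on the carbonyl carbon and says nothing about an added chloro on the aromatic ring. Among the compounds with values here, with no step of this kind measured, the expectation for compound 4 is a step of a 1.2-fold lower number from compound 3 to compound 4 (0.09 log units; within the scatter) in this assay, that is no movement beyond the scatter in either direction. Compound 4 is therefore estimated at 22000 nM in this assay, with a range from 8000 nM to 55000 nM.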

Compound 4, concentration for 50% growth inhibition: 18000 nM
The estimate for compound 4 lay 1.2-fold (0.09 log units) above the measured number; measured number inside the range.
By their numbers in this assay, from the lowest: compounds 4, 1, 3 and 2 (each within the scatter of the next, the first and the last beyond it).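

In this assay, for the compounds shown here, chloro in place of hydrogen on an aromatic carbon, ortho to a chloro group and meta to a group of 8 heavy atoms, gives a 1.5-fold lower number from compound 3 to compound 4 (0.17 log units; within the scatter) as the first measured change on this aromatic ring. The position therefore takes a second chloro with no movement beyond the scatter, and this single pair sets no direction for the change and supports no trend. No measurement at hand bears on the reason for this result.

As far as these compounds go, whether a different group at this position, such as an amine, a methoxy group or a carboxylic acid, would move the number beyond the scatter remains open, as does the effect of placing a single chloro elsewhere on the ring. Also open, from the compounds shown here alone, is whether the same added chloro would give a comparable step on the (4-chlorophenyl)amino group of compound 1, whose core differs from that of compound 3 and compound 4.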